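The compounds below may be only part of what the source reports. "The series", "measured", "known", "first", "only" and "open" are said of these compounds alone.

Measured so far in a functional assay on A549 cells (Homo sapiens) for antiproliferative activity, read by MTT assay, with a stated time of 72 h; on this read-out lower numbers stand for stronger inhibition and higher numbers for weaker inhibition:

- compound 1, `O=C1O[C@H]([C@@H](O)Cn2cc(-c3cc(F)cc(F)c3)nn2)C(OCc2ccccc2)=C1OCc1ccccc1`: 41200 nM
- compound 2, `C[Si](C)(C)c1cn(C[C@H](O)[C@H]2OC(=O)C(OCc3ccccc3)=C2OCc2ccccc2)nn1`: 19200 nM
- compound 3, `Cc1ccc(-c2cn(C[C@H](O)[C@H]3OC(=O)C(OCc4ccccc4)=C3OCc3ccccc3)nn2)cc1`: 8690 nM

Compound 3 gives the lowest of the three numbers; the gaps to it are a 2.2-fold lower number from compound 2 to compound 3 (0.34 log units; beyond the scatter) and a 4.7-fold lower number from compound 1 to compound 3 (0.68 log units; beyond the scatter), both beyond the scatter, and between the other two compounds the step is a 2.1-fold lower number from compound 1 to compound 2 (0.33 log units; beyond the scatter).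

Compound 4, `O=C1O[C@H]([C@@H](O)Cn2cc(CNS(=O)(=O)c3ccc(Cl)cc3)nn2)C(OCc2ccccc2)=C1OCc1ccccc1`, is not yet measured. It differs from compound 3 only by (((4-chlorophenyl)sulfonyl)amino)methyl in place of 4-methylphenyl on an aromatic carbon.

All three measured steps change the group on the same aromatic carbon of the five-membered ring, so all bear on this change, and none is large: the whole spread of the series is covered by a 4.7-fold lower number from compound 1 to compound 3 (0.68 log units; beyond the scatter). None of them, however, brings in a hydrogen-bond donor, acceptors or a group of this size, so the direction is not fixed by the data. The aromatic-ring groups sit at both ends of the measured range, which argues against a sharp move either way. The expectation is a modest step toward a higher number, a 1.7-fold higher number from compound 3 to compound 4 (0.24 log units; within the scatter), with a wide range.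

Compound 4 is therefore estimated at 15000 nM, between 5000 nM and 45000 nM.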

Compound 4, half-maximal inhibitory concentration: 2870 nM
Beside the measured number, compound 4's estimate is 5.2-fold (0.72 log units) above it; measured number below the stated range.
By their numbers in this assay, from the lowest: compound 4; then compound 3; then compound 2; then compound 1.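

In this assay, the aromatic carbon of the five-membered aromatic ring with 3 nitrogen accepts (((4-chlorophenyl)sulfonyl)amino)methyl, a larger group than any earlier one at this position and the only one here with a hydrogen-bond donor and hydrogen-bond acceptors, with a 3.0-fold lower number from compound 3 to compound 4 (0.48 log units; beyond the scatter) in place of 4-methylphenyl. Against the remaining compounds the same group gives a 6.7-fold lower number from compound 2 to compound 4 (0.83 log units; beyond the scatter) and a 14-fold lower number from compound 1 to compound 4 (1.16 log units; beyond the scatter), the second being the only large step in the series, so compound 4 holds the lowest number of the four, with all its steps beyond the scatter, and an aromatic ring directly on this carbon is not needed for the lowest number seen so far. No measurement available here bears on what lies behind this gain.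

With a single compound of this type, the shift cannot be assigned to the sulfonylamino link, the methyl spacer or the 4-chlorophenyl end. Going by these compounds, it also remains open how a simple aminomethyl group, a carboxylic acid or a longer chain ending in the same 4-chlorophenylsulfonyl unit would read on this carbon.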